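Swapping One Ring for Another on a Sulfonyl Sulfur

The source may report more compounds than this note shows. Statements on the series, on what has been measured and on what is new or still open speak of the compounds shown alone.

Compound 1 `O=S(=O)(c1ccc(F)cc1)c1cc(F)c(O)c2ncccc12` and compound 2 `O=S(=O)(c1cc(F)c(O)c2ncccc12)C1CCCC1` share a core and differ only in the group on the sulfonyl sulfur. In an ADME assay on Cerebrospinal fluid (Rattus norvegicus, strain Sprague-Dawley) for protein binding, using equilibrium dialysis, tested at 2 uM, compound 1 gives 53% and compound 2 gives 57%. Among the measured compounds shown here, the one measured step between them is a 1.1-fold lower unbound fraction from compound 1 to compound 2 (0.04 log units; within the scatter), so compound 2 stands level with compound 1 on these numbers.

Compound 3 `O=S(=O)(c1cc(F)c(O)c2ncccc12)N1CCCC1` keeps the same core and alters that group again, with pyrrolidin-1-yl in place of cyclopentyl on a sulfonyl sulfur. For the measured compounds named here, no measured compound carries pyrrolidin-1-yl, so the only guide is the earlier exchange at this same place, which swapped cyclopentyl in for 4-fluorophenyl. Going by the values given here, that guide is thin, but it points one way: with a 1.1-fold lower unbound fraction from compound 1 to compound 2 (0.04 log units; within the scatter) as the sole evidence, no step beyond the scatter is expected in this assay, in either direction. The expected step is a 1.0-fold higher unbound fraction from compound 2 to compound 3 (0.02 log units; within the scatter). For compound 3 the estimated value is 55%, with an expected range from 40% to 68%.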

Compound 3, plasma protein binding: 51%
The estimate for compound 3 lay 1.1-fold (0.04 log units) (unbound fraction) below the measured number; the measured number falls inside the stated range.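

In this assay the exchange of cyclopentyl for pyrrolidin-1-yl on the sulfonyl sulfur gives a 1.1-fold higher unbound fraction from compound 2 to compound 3 (0.06 log units; within the scatter), and the wider exchange of 4-fluorophenyl for pyrrolidin-1-yl gives a 1.0-fold higher unbound fraction from compound 1 to compound 3 (0.02 log units; within the scatter). Among the compounds shown here, the earlier compounds had tested only two groups made of carbon rings, whereas this result adds a five-membered ring with a nitrogen atom attached directly to the sulfur, and all three compounds still stand level, with none going against that reading. Nothing available here explains why these three groups give matching read-outs.

On these data alone, all three groups are single rings, so it remains open whether a carboxylic acid, an open-chain amine or a longer carbon chain on the sulfonyl sulfur would shift the read-out beyond the usual scatter. The level result also speaks only for this one place on the shared core and for this one measurement of binding, so it cannot be carried over to changes made elsewhere on the core.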